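Replacing the dimethoxyphenyl on the carbonyl: compound 3

The compounds below may be only part of what the source reports. "The series", "measured", "known", "first", "only" and "open" are said of these compounds alone.

Within the data shown here, compound 1 `COc1ccc(-c2cc3ccccc3nc2/C=C/C(=O)c2ccc(OC)cc2OC)cc1` gives 2260 nM in a functional assay on SK-BR-3 cells (Homo sapiens) for antiproliferative activity, read by XTT assay, with a stated time of 72 h (on this read-out lower numbers stand for stronger inhibition and higher numbers for weaker inhibition), the highest of the two numbers so far. Compound 2 `COc1ccc(-c2cc3ccccc3nc2/C=C/C(=O)c2ccccn2)cc1` gives 370 nM in this assay, with a 6.1-fold lower number from compound 1 to compound 2 (0.79 log units; beyond the scatter). Compound 3 `COc1ccc(-c2cc3ccccc3nc2/C=C/C(=O)c2sccc2N)cc1` is not yet measured; it differs from compound 1 by 3-aminothiophen-2-yl in place of 2,4-dimethoxyphenyl on a carbonyl carbon. Among the measured compounds shown here, the only step that bears on it exchanges the same group at the same place and gave a 6.1-fold lower number from compound 1 to compound 2 (0.79 log units; beyond the scatter), so a lower number is expected, though the entering ring differs and the size is uncertain. For compound 3 the expected step is a 4.1-fold lower number from compound 1 to compound 3 (0.61 log units; beyond the scatter), giving an estimate of 550 nM with a range of 150 nM to 2000 nM.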

Compound 3, half-maximal inhibitory concentration: > 10000 nM
Compound 3 gave a limit, no number; the forecaster's own chance of this, stated with the estimate: 5%; middle value at least 18-fold (1.25 log units) from the limit.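

Compound 3 gives a limit and not a number: the limit of > 10000 nM in this assay, at which 1 of the 3 values shown sits. Exchange of the ring on the carbonyl carbon does not run one way: 3-aminothiophen-2-yl gives an at least 4.4-fold higher number from compound 1 to compound 3 (0.64 log units; beyond the scatter), against a 6.1-fold lower number from compound 1 to compound 2 (0.79 log units; beyond the scatter) for pyridin-2-yl. The two entering rings also part widely, with an at least 27-fold higher number from compound 2 to compound 3 (1.43 log units; beyond the scatter), so the outcome at this place depends on the ring that enters.

On these data alone, it remains open whether the loss goes with the amine or with the sulfur ring; an unsubstituted thiophen-2-yl and an aminophenyl would separate the two. As far as these compounds go, how far compound 3 lies past its limit also stays open.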